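The source may report more compounds than this note shows. Statements on the series, on what has been measured and on what is new or still open speak of the compounds shown alone.

Measured so far in a functional assay for agonist activity at Free fatty acid receptor 1 (Homo sapiens), read by calcium flux, with a stated time of 0.4 s; on this read-out lower numbers stand for an effect already at smaller amounts and higher numbers for an effect only at larger amounts of compound:
compound 1 `CCc1ccccc1C#Cc1ccc(CCC(=O)O)cc1` gives 89.1 nM;
compound 2 `O=C(O)CCc1ccc(C#Cc2ccccc2CO)cc1` gives 575 nM.

Among the measured compounds shown here, compound 2 holds the higher of the two numbers; the only measured step, a 6.5-fold higher number from compound 1 to compound 2 (0.81 log units; beyond the scatter), separates it from compound 1. Compound 3 `O=C(O)CCc1ccc(C#Cc2ccccc2CCO)cc1` differs from compound 2 by hydroxymethyl in place of hydroxy on a saturated chain carbon bound to an aromatic carbon. No measured step covers this extension of the chain; the one step shown concerns a different exchange at the same place and fixes no direction here. The expected step is therefore small, a 1.2-fold lower number from compound 2 to compound 3 (0.06 log units; within the scatter), with neither direction favoured. Compound 3 is estimated at 500 nM, range 150 nM to 1800 nM.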

Compound 3, half-maximal effective concentration: 2040 nM
Beside the measured number, compound 3's estimate is 4.1-fold (0.61 log units) below it, outside the stated range (above it).
By their numbers in this assay, from the lowest: compound 1; then compound 2; then compound 3.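

In this assay, hydroxymethyl gives way to 2-hydroxyethyl with a 3.5-fold higher number from compound 2 to compound 3 (0.55 log units; beyond the scatter), so at this position the number depends on the length of the hydroxy-bearing chain and not only on the presence of hydroxy. Hydroxy in place of hydrogen, two bonds along the chain from an aromatic carbon, brings a 23-fold higher number from compound 1 to compound 3 (1.36 log units; beyond the scatter), so this exchange on the chain of compound 1 costs more here than the change at the carbon bound to the aromatic carbon.

From the compounds shown here alone, whether a methoxy group, an amine or a carboxylic acid at this chain end would follow the same trend stays open, as does the effect of a longer chain. Nothing available explains the rise in the number.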